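This account rests on a few compounds, and the source may have more. Where it says the series, first, only, none or still open, it means among the compounds named here.

Three compounds sharing one core were examined, compound 1 `Cc1cc(C(=O)O)ccc1C(C)N1CCC[C@H](O[C@H](CO)c2cc(Cl)cc(Cl)c2)[C@@H]1c1ccccc1`, compound 2 `Nc1cc(C(=O)O)ccc1CN1CCC[C@H](O[C@H](CO)c2cc(Cl)cc(Cl)c2)[C@@H]1c1ccccc1` and compound 3 `Cc1nc(C(=O)O)ccc1CN1CCC[C@H](O[C@H](CO)c2cc(Cl)cc(Cl)c2)[C@@H]1c1ccccc1`, together with a fourth, compound 4 `O=C(O)C12CC(CN3CCC[C@H](O[C@H](CO)c4cc(Cl)cc(Cl)c4)[C@@H]3c3ccccc3)(C1)C2`, that has not yet been tested. In an assay on isolated protein for activation of cGMP-dependent protein kinase 1 (Homo sapiens), read by ADP-Glo, with stated times of 30 min and 2 h (on this read-out higher numbers stand for an effect only at larger amounts of compound and lower numbers for an effect already at smaller amounts), compound 2 gives 168000 nM, and compound 3 gives 144000 nM. For compound 1 the entry reads "nd" (no result reported), that is, no result was reported. Among the compounds with values here, compound 3 thus stands among only two numbers, and the step of a 1.2-fold lower number from compound 2 to compound 3 (0.07 log units; within the scatter) is too small to set the two apart.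

Compound 4 differs from compound 3 in one place: a group of 8 heavy atoms (6 carbon, 2 oxygen; 2 four-membered non-aromatic rings of carbon only) in place of a group of 10 heavy atoms (7 carbon, 1 nitrogen, 2 oxygen; one six-membered aromatic ring with 1 hetero atom), on a saturated chain carbon bound to an amine nitrogen in a ring. Within the data shown here, the only measured step, from compound 2 to compound 3, swaps one six-membered aromatic ring for another and leaves this assay untouched; no measured step trades an aromatic ring for two four-membered non-aromatic rings of carbon only, so there is nothing to lean on for the direction of the change. Both measured compounds act only at very large amounts, and the expectation is therefore that compound 4 stays in the same region, with an estimated step of a 1.0-fold higher number from compound 3 to compound 4 (0.02 log units; within the scatter) that is not expected to exceed the scatter. For compound 4 the estimated value is 150000 nM, expected to fall between 40000 nM and 600000 nM.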

Compound 4, half-maximal effective concentration: > 200000 nM
Compound 4: no number, only a limit; the forecaster's own chance of this, stated with the estimate: 30%; middle value at least 1.3-fold (0.12 log units) away from the limit.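

Compound 4 gives no number in this assay, only a limit: > 200000 nM. Read as floors, an at least 1.3-fold higher number from compound 3 to compound 4 (0.14 log units; that floor lies within the scatter) and an at least 1.1-fold higher number from compound 2 to compound 4 (0.07 log units; that floor lies within the scatter) both stay within the scatter, so the true size of either step cannot be read, but neither points towards an effect at smaller amounts. Compounds 2 and 3 carry only six-membered aromatic rings at this place, whereas compound 4 puts 2 four-membered non-aromatic rings of carbon only on the saturated chain carbon bound to an amine nitrogen in a ring, and the reading then ends at the top of what is reported: the limit of > 200000 nM in this assay, at which 1 of the 4 values shown sits.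

Whether compound 4 lies just past its limit or far beyond it stays open, and since every number shown requires very large amounts of compound, the series offers no active member against which to judge this change. As far as these compounds go, how a longer chain ending in a carboxylic acid, or a single saturated six-membered ring carrying a carboxylic acid, would read at this place also stays open.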